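The source may hold more compounds than are shown below. What is called first, only, known or untested is meant among the compounds shown, and "the series" means these compounds.

Series notes. Compound 1 `CCCNc1nc(NCc2ccc(C(=O)Nc3ccc(F)cc3)cc2)c2cc(C)ccc2n1` is the reference point here. In a functional assay on SW480 cells (Homo sapiens) for inhibition, read by luminescence and resazurin assay, with a stated time of 3 days (a lower number here means a stronger inhibitor, a higher number a weaker inhibitor), compound 1 gives 1300 nM. Compound 2 `Cc1ccc2nc(N(C)C)nc(NCc3ccc(C(=O)NCc4ccc(F)cc4)cc3)c2c1` gives 1100 nM, which sits within the scatter of compound 1, so no order between them is claimed. Among the measured compounds shown here, compound 3 `C=CCNc1nc(NCc2ccc(C(=O)Nc3ccc(F)cc3)cc2)c2cc(C)ccc2n1` gives 10000 nM; the step of a 7.7-fold higher number from compound 1 to compound 3 (0.89 log units; beyond the scatter) is the only change in the set whose effect lies beyond the scatter, and it concerns a saturated chain carbon bound to a nitrogen on the aromatic ring, not the fused ring itself. Of the three numbers, compound 1 stands second highest, nearest to compound 2 and furthest from compound 3.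

Compound 4 `CCCNc1nc(NCc2ccc(C(=O)Nc3ccc(F)cc3)cc2)c2ccccc2n1` differs from compound 1 by hydrogen in place of methyl on an aromatic carbon. For the measured compounds named here, no measured pair in this set changes that aromatic carbon, so no step bears directly on the move to compound 4; the one step beyond the scatter, from compound 1 to compound 3, lies elsewhere. The expectation for compound 4 is therefore a step of a 1.2-fold higher number from compound 1 to compound 4 (0.09 log units; within the scatter), in no firm direction. Compound 4 is estimated at 1600 nM, expected between 500 nM and 5000 nM.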

Compound 4, half-maximal inhibitory concentration: 1600 nM
Compound 4: middle estimate and measured number agree at the digits printed, within the range that was stated.
By their numbers in this assay, from the lowest: compounds 2, 1 and 4 (each within the scatter of the next); then compound 3.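

In this assay, among the compounds shown here, hydrogen in place of methyl on this aromatic carbon gives a 1.2-fold higher number from compound 1 to compound 4 (0.09 log units; within the scatter), the first direct reading at this position. On the background of compound 1, the methyl, meta to a fused ring and para to a fused ring, is therefore not needed to keep the number at this level, and this one pair shows no measurable gain or loss from it. No supporting evidence bears on this result.

As far as these compounds go, whether the position tolerates other groups stays open: a chlorine, a methoxy group, an amine or a longer chain on this carbon could still move the number. Also open, from the compounds shown here alone, is whether removing the methyl has as little effect when the rest of the molecule is that of compound 2 or compound 3.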